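The source may hold more compounds than are shown below. What is called first, only, known or untested is meant among the compounds shown, and "the series" means these compounds.

Compounds measured in an ADME assay (liver) for metabolic stability, with Liver microsome (Homo sapiens) as the target, read by LC-MS, using microsomes, tested at 1 uM; on this read-out higher numbers stand for a longer-lived compound and lower numbers for a shorter-lived compound:
compound 1, `CCN(CC)CCCCN/C(=N\c1ccnc2cc(Cl)ccc12)C(C)C`: 0.917 h
compound 2, `CCN(CC)CCCCN/C(C)=N\c1ccnc2cc(Cl)ccc12`: > 1 h, a limit of the assay, not a number
compound 3, `CN(C)CCC/N=C(\c1ccccc1)N(CCCN(C)C)c1ccnc2cc(Cl)ccc12`: > 1 h, likewise a limit of the assay

Compound 2 stands at the limit of > 1 h in this assay, at which 2 of the 3 values shown sit; only compound 1 gives a number. Going by the values given here, the single measured one-place step, an at least 1.0-fold higher number from compound 1 to compound 2 (0.03 log units; that floor lies within the scatter), is within scatter and concerns the group on the carbon doubly bonded to nitrogen, not the chain. Compound 4, `CCN(CC)CCCCCN/C(C)=N\c1ccnc2cc(Cl)ccc12`, differs from compound 2 by (diethylamino)methyl in place of diethylamino on a saturated chain carbon, four bonds along the chain from an amine nitrogen. Among the compounds with values here, no measured step touches this chain lengthening, so no step beyond the scatter is expected in this assay; compound 4 is expected to sit at the limit again. The estimate for compound 4 is 1.1 h, with a range from 0.6 h to 2.2 h, which means an expected step that the limit leaves unreadable from compound 2 to compound 4.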

Compound 4, half-life: 0.933 h
Estimate against measurement, compound 4: 1.2-fold (0.07 log units) above; measured number inside the range.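

Going by these compounds alone, the first reading for a change on the chain, in this assay, is an at least 1.0-fold lower number from compound 2 to compound 4 (0.03 log units; that floor lies within the scatter): moving from diethylamino to (diethylamino)methyl at this position gives no step beyond the scatter as far as can be read. Only the floor of that step is available, so a larger drop is not excluded. Compound 2 holds a limit of the assay, not a number: the limit of > 1 h in this assay, at which 2 of the 4 values shown sit.

Still open, from the compounds shown here alone, is how 2-(diethylamino)ethyl or 3-(diethylamino)propyl would read at this position. Also open, going by these compounds, is whether a hydroxyl on the chain would change the half-life.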